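Chloro for fluoro on the benzyl ring of the hydroxamic acid compounds

The source may report more compounds than this note shows. Statements on the series, on what has been measured and on what is new or still open speak of the compounds shown alone.

Compound 1 `O=C(/C=C/c1ccc(OCc2nc(C3CCN(Cc4ccccc4F)CC3)no2)cc1)NO` is tested in an assay on isolated protein for inhibition of protein deacetylase HDAC6 (Homo sapiens), read by fluorescence, with a stated time of 1 h, tested at 100 nM (on this read-out lower numbers stand for less inhibition and higher numbers for more inhibition at the one concentration tested (going by the name of the read-out)), where compound 1 gives 68%. Compound 2 `O=C(/C=C/c1ccc(OCc2nc(C3CCN(Cc4ccccc4Cl)CC3)no2)cc1)NO` carries the change (chloro in place of fluoro on an aromatic carbon), and in this assay compound 2 gives 59%, a step of a number 9 percentage points lower from compound 1 to compound 2 (within the scatter). Compound 3 `CN(Cc1nc(C2CCN(Cc3ccc(F)cc3F)CC2)no1)c1ncc(C(=O)NO)cn1` rests on a different core, and the difference between the two cores is not broken down here; in this assay compound 3 gives 66%. Compound 4 `CN(Cc1nc(C2CCN(Cc3ccc(F)cc3Cl)CC2)no1)c1ncc(C(=O)NO)cn1` differs from compound 3 by chloro in place of fluoro on an aromatic carbon, the same kind of change as before, though here the place is also meta to a fluoro group. Because the earlier step of a number 9 percentage points lower from compound 1 to compound 2 (within the scatter) stayed within the scatter, the step from compound 3 to compound 4 is expected to be about as small, a number 7 percentage points lower from compound 3 to compound 4 (within the scatter). Compound 4 is therefore estimated to give 59% in this assay, expected to lie between 45% and 72%.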

Compound 4, a percentage reported as inhibition, at one concentration (the size of the read-out at that concentration, not a potency): 49%
Beside the measured number, compound 4's estimate is 10 percentage points above it; low and high end bracket the measured number.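

In this assay, chloro in place of fluoro gives a number 17 percentage points lower from compound 3 to compound 4 (beyond the scatter). Set beside the earlier step, this larger step cannot be told apart from it, so the change carries over to the second core without a measurable difference in size: the same change on two cores in this assay, a number 9 percentage points lower (within the scatter) from compound 1 to compound 2 and a number 17 percentage points lower (beyond the scatter) from compound 3 to compound 4, 8 percentage points apart, within the scatter of two such steps. Among the compounds shown here, this does not show that the two steps are equal or that the core has no bearing on the step, and the second pair also carries a further fluoro group that compound 1 and compound 2 lack, so the two influences are not separated.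

The compounds shown leave open how bromo, methoxy or a nitrile would read in place of the chloro. They also leave open whether the change behaves alike on any third core.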